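A few compounds are considered here, and "the series" means these few. Any claim that something is new, unique, unknown or untested is made for them only; others in the source may bear on it.

Compound 1 `CCCCCCCCCCCCS(=O)(=O)NC(=O)Nc1c(C(C)C)cccc1C(C)C` carries a dodecyl sulfonylurea on a di-isopropyl-substituted core. Going by the values given here, in an assay on microsomes from liver for inhibition of sterol O-acyltransferase 1 (Rattus norvegicus) (on this read-out lower numbers stand for stronger inhibition and higher numbers for weaker inhibition), compound 1 gives 3300 nM, the highest of the two numbers recorded here; its only neighbour, compound 2 `CCCCCCCCCCCCS(=O)(=O)N(C)C(=O)Nc1c(C(C)C)cccc1C(C)C`, in which the sulfonamide nitrogen carries a methyl, gives 675 nM in this assay, and the step of a 4.9-fold lower number from compound 1 to compound 2 (0.69 log units; beyond the scatter) is the one measured change in the set. Compound 3 `CCCCCCCCCCCCCCCCS(=O)(=O)NC(=O)Nc1c(C(C)C)cccc1C(C)C` differs from compound 1 by butyl in place of hydrogen on a saturated chain carbon, ten or more bonds along the chain from a sulfonyl sulfur, so the sulfonyl chain grows from dodecyl to hexadecyl while the urea and the core stay untouched. Among the compounds with values here, no measured step concerns the chain length: the single step from compound 1 to compound 2 alters the nitrogen, not the alkyl tail, and so offers no guide here. With nothing to lean on, compound 3 is expected to sit close to compound 1 in this assay, with a step of no change at the digits printed from compound 1 to compound 3 (within the scatter) that may well stay within the scatter; the estimate for compound 3 is 3300 nM, ranging from 900 nM to 12000 nM.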

Compound 3, half-maximal inhibitory concentration: 1270 nM
Compound 3: middle estimate off by 2.6-fold (0.41 log units), on the high side, and the stated range covers the measured number.
By their numbers in this assay, from the lowest: compounds 2 and 3 (each within the scatter of the next); then compound 1.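

In this assay, the step from dodecyl to hexadecyl gives a 2.6-fold lower number from compound 1 to compound 3 (0.41 log units; beyond the scatter), so the far end of the sulfonyl chain is a place where a change moves the number beyond the scatter. Going by these compounds alone, the nitrogen of compound 2 is therefore not the only site in compound 1 that responds, and here the added butyl goes with stronger inhibition, not weaker. No measurement given here accounts for this shift.

As far as these compounds go, two chain lengths fix no trend, so it remains open whether a shorter octyl chain, a longer octadecyl chain or a chain ending in a carboxylic acid would continue this direction. From the compounds shown here alone, it is also open whether the methyl on the sulfonamide nitrogen and the hexadecyl chain would add up when carried together in one compound.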